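Thiourea series: Vero cell cytotoxicity, towards compound 3

The source may hold more compounds than are shown below. What is called first, only, known or untested is meant among the compounds shown, and "the series" means these compounds.

Two numbers exist so far in an ADME assay on Vero 76 cells (Chlorocebus sabaeus) for cytotoxicity, read by crystal violet staining, with a stated time of 96 h; a lower number here means that less compound is tolerated, a higher number that more compound is tolerated. Compound 1 `FC(F)(F)c1cccc(NC(=S)Nc2ccc(Cl)cc2)c1` gives 11000 nM. Compound 2 `CCCC[C@H]1CC[C@H](c2ccc(NC(=S)Nc3cccc(C(F)(F)F)c3)cc2)CC1` gives 17000 nM in this assay, and the step of a 1.5-fold higher number from compound 1 to compound 2 (0.19 log units; within the scatter) is within the scatter. Compound 3 `Fc1ccccc1NC(=S)Nc1cccc(C(F)(F)F)c1` differs from compound 1 by 2-fluorophenyl in place of 4-chlorophenyl on an amide-type nitrogen. Among the measured compounds shown here, no measured step touches this change; the one step at hand is the exchange at the aromatic carbon, which stayed within the scatter, so nothing beyond the scatter is expected in this assay. For compound 3 the expected value is 11000 nM, with a range of 5000 nM to 25000 nM. The expected step is no change at the digits printed from compound 1 to compound 3 (within the scatter).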

Compound 3, half-maximal cytotoxic concentration: 64000 nM
Beside the measured number, compound 3's estimate is 5.8-fold (0.76 log units) below it; measured number above the stated range.
By their numbers in this assay, from the lowest: compounds 1 and 2 (each within the scatter of the next); then compound 3.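

In this assay 2-fluorophenyl in place of 4-chlorophenyl on the amide-type nitrogen gives a 5.8-fold higher number from compound 1 to compound 3 (0.76 log units; beyond the scatter) and lies beyond the scatter, whereas the exchange on the aromatic carbon gave a 1.5-fold higher number from compound 1 to compound 2 (0.19 log units; within the scatter) and stayed within it. This nitrogen substituent is thus the first place in the series where the number moves, though on a single pair. Nothing measured bears on the cause of this step.

The change swaps chlorine for fluorine and alters the numbered ring position together, so the two remain unseparated. Going by these compounds, whether 2-chlorophenyl, 4-fluorophenyl or unsubstituted phenyl on this nitrogen follows compound 3 or compound 1 remains open.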